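A few compounds are considered here, and "the series" means these few. Any claim that something is new, unique, unknown or untested is made for them only; others in the source may bear on it.

Working notes on the amide series. Compound 1 `COC(=O)c1nc(Br)c2cccnc2c1N[C@H]1CC[C@H](N)CC1` is the ester; in a functional assay on SK-BR-3 cells (Homo sapiens) for cytotoxicity, read by MTT assay, with a stated time of 72 h (on this read-out lower numbers stand for stronger inhibition and higher numbers for weaker inhibition), compound 1 gives "not determined" (no result reported). Compound 2 `N[C@H]1CC[C@H](Nc2c(C(=O)NCc3ccc(Cl)cc3Cl)nc(Br)c3cccnc23)CC1` carries the 2,4-dichlorobenzyl amide, and compound 2 gives 6000 nM. Compound 3 `N[C@H]1CC[C@H](Nc2c(C(=O)NC3CCCCC3)nc(Br)c3cccnc23)CC1` carries the cyclohexyl amide, and compound 3 gives 4200 nM. Among the compounds with values here, the single step between them, a 1.4-fold lower number from compound 2 to compound 3 (0.15 log units; within the scatter), stays within the scatter, so compound 3 and compound 2 cannot be told apart on these numbers; compound 3 simply holds the lower of the two values reported.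

Compound 4 `N[C@H]1CC[C@H](Nc2c(C(=O)NCc3ccccc3)nc(Br)c3cccnc23)CC1` is the next member: benzyl in place of cyclohexyl on an amide-type nitrogen. Within the data shown here, the only step that bears on it is the one from compound 2 to compound 3, where cyclohexyl replaced 2,4-dichlorobenzyl with no change beyond the scatter. Benzyl sits between those two groups, so the step of a 1.2-fold higher number from compound 3 to compound 4 (0.08 log units; within the scatter) is expected to stay within the scatter. Compound 4 is therefore estimated at 5000 nM, with a range from 2500 nM to 10000 nM.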

Compound 4, half-maximal inhibitory concentration: 8000 nM
For compound 4 the middle estimate is 1.6-fold (0.20 log units) below the measured one, and the stated range covers the measured number.
By their numbers in this assay, from the lowest: compounds 3, 2 and 4 (each within the scatter of the next).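

In this assay, the new amide can be set against two neighbours: benzyl in place of cyclohexyl gives a 1.9-fold higher number from compound 3 to compound 4 (0.28 log units; within the scatter) and phenyl in place of 2,4-dichlorophenyl gives a 1.3-fold higher number from compound 2 to compound 4 (0.12 log units; within the scatter) and both steps stay within the scatter. On the amide-type nitrogen, then, neither swapping the non-aromatic ring for the aromatic one nor taking away the two chlorines separates compound 4 from compound 2 or compound 3, so these three amides cannot be told apart on these numbers. No supporting data bear on why the position tolerates these changes.

With compound 1 at "not determined" (no result reported) the ester cannot be compared with the amides. As far as these compounds go, whether any group on this nitrogen moves the number beyond the scatter stays open, for instance an aminoethyl chain, a longer alkyl chain or a carboxylic acid on the benzyl ring.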